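A trifluoromethyl on the phenyl ring of compound 3

The compounds below may be only part of what the source reports. "The series", "measured", "known", "first", "only" and "open" are said of these compounds alone.

Compound 1 `Cn1c(C(F)(F)F)nc2cc(Cl)c(Cl)cc21`: 56000 nM
Compound 2 `FC(F)(F)c1nc2cc(Cl)c(Cl)cc2n1CC1CC1`: 61300 nM
Compound 3 `FC(F)(F)c1nc2cc(Cl)c(Cl)cc2n1Cc1ccccc1`: 8600 nM

In a functional assay on HCT-116 cells (Homo sapiens) for cytotoxicity, read by MTT assay, with a stated time of 48 h (on this read-out lower numbers stand for stronger inhibition of growth and higher numbers for weaker inhibition of growth), compound 3 stands lowest of the three at 8600 nM. Compound 4 `FC(F)(F)c1ccc(Cn2c(C(F)(F)F)nc3cc(Cl)c(Cl)cc32)cc1` carries trifluoromethyl in place of hydrogen on an aromatic carbon, para to a large group (trifluoromethyl in place of hydrogen on an aromatic carbon). Phenyl in place of hydrogen gave a 6.5-fold lower number from compound 1 to compound 3 (0.81 log units; beyond the scatter), and phenyl in place of cyclopropyl gave a 7.1-fold lower number from compound 2 to compound 3 (0.85 log units; beyond the scatter). Cyclopropyl in place of hydrogen gave a 1.1-fold higher number from compound 1 to compound 2 (0.04 log units; within the scatter), within the scatter. Within the data shown here, no measured step changes a group on the phenyl ring itself, so these sizes do not carry over directly. Only a small move toward lower numbers is expected. The estimated change is a 1.4-fold lower number from compound 3 to compound 4 (0.16 log units; within the scatter). For compound 4 the estimated value is 6000 nM, with an expected range of 2000 nM to 18000 nM.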

Compound 4, concentration for 50% growth inhibition: 19000 nM
Compound 4: the middle estimate sits 3.2-fold (0.50 log units) below what was measured; the measured number lies above the stated range.
By their numbers in this assay, from the lowest: compound 3; then compound 4; then compounds 1 and 2 (each within the scatter of the next).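

In this assay, trifluoromethyl in place of hydrogen on an aromatic carbon, para to a large group, gave a 2.2-fold higher number from compound 3 to compound 4 (0.34 log units; beyond the scatter) as the first change shown on the phenyl ring itself. The number at this position therefore responds to substitution, and for this group it moves upward, beyond the scatter. Nothing measured explains this shift. Going by these compounds, whether fluorine, methoxy or an amine on the same carbon would move the number the same way remains open, as does the effect of trifluoromethyl on other carbons of the ring.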